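Cytotoxicity notes on two amides and a third

The compounds below may be only part of what the source reports. "The series", "measured", "known", "first", "only" and "open" are said of these compounds alone.

Measured in an ADME assay on BEAS-2B cells (Homo sapiens) for cytotoxicity, read by fluorescence, with a stated time of 48 h; a higher number here means that more compound is tolerated, a lower number that less compound is tolerated:
- compound 1 `O=C(Nc1ccccc1)c1cc2n(n1)CCCN(C(=O)c1occc1Cl)C2`: 30000 nM
- compound 2 `Cc1ccoc1C(=O)N1CCCn2nc(C(=O)NCc3ccccc3)cc2C1`: 50000 nM

In this assay, compound 2 gives 50000 nM, which lies within the scatter of the value for compound 1, so the two compounds cannot be told apart on these numbers. Next in the series is compound 3 `COc1ccc(NC(=O)c2cc3n(n2)CCCN(C(=O)c2occc2C)C3)cc1`. The structural change from compound 2 is 4-methoxyphenyl in place of benzyl on an amide-type nitrogen. Within the data shown here, no two measured compounds differ in one place only, so no measured step guides this change. With compound 1 at 30000 nM and compound 2 at 50000 nM, the expectation is for no shift beyond the scatter, in either direction. The expected change is a 1.3-fold lower number from compound 2 to compound 3 (0.10 log units; within the scatter). For compound 3 the estimate is 40000 nM, with an expected range from 18000 nM to 90000 nM.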

Compound 3, half-maximal cytotoxic concentration: 90000 nM
Compound 3: middle estimate off by 2.3-fold (0.35 log units), on the low side; measured number inside the range.
By their numbers in this assay, from the lowest: compounds 1, 2 and 3 (each within the scatter of the next, the first and the last beyond it).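

In this assay, among these compounds, 4-methoxyphenyl in place of benzyl on an amide-type nitrogen gives a 1.8-fold higher number from compound 2 to compound 3 (0.26 log units; within the scatter), the first step that changes one place only. On this pair, the position accepts a move from benzyl, with 7 heavy atoms, to 4-methoxyphenyl, with 8 heavy atoms and 1 hydrogen-bond acceptor, without a shift that can be told from the scatter.

From the compounds shown here alone, it remains open whether this holds for other groups at the same nitrogen, such as a longer chain like phenethyl, or for a phenyl ring carrying a dimethylamino group or a carboxylic acid. Among the compounds shown here, the single step also cannot separate the methoxy group from the replacement of benzyl by an aryl group. No supporting evidence bears on this step.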